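Chloro in Place of Iodo: Expectations for Compound 4

The source may report more compounds than this note shows. Statements on the series, on what has been measured and on what is new or still open speak of the compounds shown alone.

Compound 1 `CCC[C@@H](O)C1=C(Br)/C(=C/I)OC1=O` was tested in a functional assay on LNCaP cells (Homo sapiens) for cytotoxicity; a lower number here means that less compound is needed, a higher number that more compound is needed for the effect. Going by the values given here, compound 1 gives < 0.1 ug/mL, which is a limit of the assay rather than a number, and it is the one measured compound that sits at the limit of < 0.1 ug/mL in this assay, at which 1 of the 3 values shown sits. Compound 2 `CCC[C@@H](OC(C)=O)C1=C(Br)[C@@](C)(OC)OC1=O` gives 1.7 ug/mL in this assay. Compound 3 `CCC[C@@H](OC(C)=O)C1=C(Br)/C(=C/I)OC1=O` gives 2 ug/mL in this assay. Among the compounds with values here, the single step among the measured compounds that changes one place is an at least 20-fold higher number from compound 1 to compound 3 (1.30 log units; beyond the scatter), the change being acetyl in place of hydrogen on an oxygen on a saturated carbon.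

Compound 4 `CCC[C@@H](O)C1=C(Br)/C(=C/Cl)OC1=O` has not yet been measured. It differs from compound 1 in one place: chloro in place of iodo on a double-bonded chain carbon bound to a double-bonded ring carbon. Within the data shown here, no measured step bears on this kind of change; the only measured step concerns the acetyl group, not the halogen on the double-bonded chain carbon. With nothing pointing toward a change, the expected step of a number no lower from compound 1 to compound 4 (the limit leaves the size open) is none beyond the usual scatter. Compound 4 is therefore estimated at 0.1 ug/mL, with a range from 0.03 ug/mL to 0.5 ug/mL.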

Compound 4, concentration for half-maximal effect: 3 ug/mL
Compound 4: the middle estimate sits 30-fold (1.48 log units) below what was measured; the whole stated range lies below it.
By their numbers in this assay, from the lowest: compounds 2, 3 and 4 (each within the scatter of the next). At a limit, below all of these: compound 1.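

In this assay, the halogen on the double-bonded chain carbon bound to a double-bonded ring carbon clearly matters: chloro in place of iodo brings an at least 30-fold higher number from compound 1 to compound 4 (1.47 log units; beyond the scatter). The earlier compounds shown here showed a large step only for the acetyl change on the oxygen, so this is a second place in compound 1 where a single change moves the number well beyond the scatter. The full size of the new step stays open, since it starts from a limit and not from a number: the limit of < 0.1 ug/mL in this assay, at which 1 of the 4 values shown sits.

The compounds shown leave open whether bromo, fluoro or a nitrile on that same carbon would behave more like iodo or like chloro. They also leave open how a longer chain on the saturated carbon would affect the number.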